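The source may report more compounds than this note shows. Statements on the series, on what has been measured and on what is new or still open speak of the compounds shown alone.

Compound 1 `c1ccc(-c2cn3ccnc3c(-c3ccc4ncn(C5CCCCC5)c4c3)n2)cc1` and compound 2 `c1cn2cc(-c3ccsc3)nc(-c3ccc4ncn(C5CCCCC5)c4c3)c2n1` share one core and differ in a single group on it. In a functional assay on HT-29 cells (Homo sapiens) for inhibition, read by sulforhodamine B assay, with a stated time of 48 h, tested at 10 uM (a higher number here means more inhibition at the concentration tested (going by the name of the read-out), a lower number less inhibition), compound 1 gives 48.3%, while compound 2 gives 5.68%, the lowest of the two numbers shown; that step, a number 42.6 percentage points lower from compound 1 to compound 2 (beyond the scatter), came with thiophen-3-yl in place of phenyl on an aromatic carbon. Compound 3 `Clc1ccc(-c2cn3ccnc3c(-c3ccc4ncn(C5CCCCC5)c4c3)n2)cc1` has not yet been measured. It differs from compound 2 as follows: 4-chlorophenyl in place of thiophen-3-yl on an aromatic carbon. Among the measured compounds shown here, the only measured step that bears on this is the large one from compound 1 to compound 2, and since compound 3, like compound 1 with its 48.3%, carries a six-membered aromatic ring of carbon only at that carbon, the new step is expected to run back upward, roughly undoing the earlier drop rather than lying within the scatter. Compound 3 is therefore estimated at 45% in this assay, between 20% and 70%, an expected step of a number 39.3 percentage points higher from compound 2 to compound 3 (beyond the scatter).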

Compound 3, a percentage reported as inhibition, at one concentration (the size of the read-out at that concentration, not a potency): 16.4%
For compound 3 the middle estimate is 28.6 percentage points above the measured one, outside the stated range (below it).
By their numbers in this assay, from the lowest: compound 2; then compound 3; then compound 1.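

In this assay, the new result shows that this position is sensitive to more than the type of ring it carries: keeping the phenyl and adding chloro in place of hydrogen gives a number 31.9 percentage points lower from compound 1 to compound 3 (beyond the scatter) on that ring alone. Going from thiophen-3-yl to 4-chlorophenyl gives only a number 10.7 percentage points higher from compound 2 to compound 3 (beyond the scatter) and recovers a modest part of the number, so a six-membered aromatic ring of carbon only at this carbon does not by itself restore the level of compound 1. Nothing at hand accounts for either step and the cause stays unknown. The compounds shown leave open whether the loss is specific to chloro or would also follow from a fluoro, methoxy or amine group on the phenyl. They also leave open how a pyridyl ring or a furan-3-yl ring would fare at this carbon.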